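A Methoxy Group Repeated on a Second Core

This account rests on a few compounds, and the source may have more. Where it says the series, first, only, none or still open, it means among the compounds named here.

Compound 1 `O=c1ccoc(/C=C/c2ccccc2)c1` gives 691 uM in a functional assay on MCF7 cells (Homo sapiens) for inhibition, read by sulforhodamine B assay, with a stated time of 48 h; on this read-out lower numbers stand for stronger inhibition of growth and higher numbers for weaker inhibition of growth. Compound 2 `COc1ccc(/C=C/c2cc(=O)cco2)cc1` differs from it by methoxy in place of hydrogen on an aromatic carbon, a change that produced a 1.7-fold lower number from compound 1 to compound 2 (0.24 log units; within the scatter). In this assay compound 2 gives 396 uM. Compound 3 `COc1cc(/C=C/C2CC=CC(=O)O2)cc(OC)c1` is built on a different core; the difference between the two cores is not broken down here. In this assay compound 3 gives 9.5 uM, the lowest of the three numbers, and its steps to compound 1 and compound 2 both lie beyond the scatter.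

Compound 4 `COc1cc(/C=C/C2CC=CC(=O)O2)cc(OC)c1OC` has not yet been measured. It differs from compound 3 by methoxy in place of hydrogen on an aromatic carbon. This is the same kind of change as that from compound 1 to compound 2, but not the same: in compound 4 the entering group is ortho to two methoxy groups as well as para to a group of 9 heavy atoms, whereas in compound 2 it is only para to a group of 9 heavy atoms. A step of about a 1.6-fold lower number from compound 3 to compound 4 (0.20 log units; within the scatter) is expected in this assay, because the earlier step of a 1.7-fold lower number from compound 1 to compound 2 (0.24 log units; within the scatter) stayed within the scatter. Compound 4 is therefore estimated at 6 uM, most likely between 2 uM and 20 uM.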

Compound 4, concentration for growth inhibition (reported as GI): 15.3 uM
Beside the measured number, compound 4's estimate is 2.6-fold (0.41 log units) below it, within the range that was stated.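

In this assay, among the compounds shown here, methoxy in place of hydrogen on an aromatic carbon gave a 1.6-fold higher number from compound 3 to compound 4 (0.21 log units; within the scatter), so on this core, as on the core of compound 1, the single step stays within the scatter. Set together, the two steps run in opposite directions, and the gap between them lies beyond the scatter of two such steps: the same change on two cores in this assay, a 1.7-fold lower number (0.24 log units; within the scatter) from compound 1 to compound 2 and a 1.6-fold higher number (0.21 log units; within the scatter) from compound 3 to compound 4, 2.8-fold (0.45 log units) apart, beyond the scatter of two such steps This shows that the step seen on the core of compound 1 did not carry over unchanged to the core of compound 3, but with only two pairs it does not show whether the core itself, or the two methoxy groups ortho to the entering group in compound 4, accounts for the gap.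

The compounds shown leave open how an amine, a carboxylic acid or a longer chain would read at the same place on either core. They also leave open how a single methoxy group would read on the core of compound 3 with no other methoxy groups on the ring.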